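Compound 4: A Carbamoyl Analogue of Compound 2

The compounds below may be only part of what the source reports. "The series", "measured", "known", "first", "only" and "open" are said of these compounds alone.

Compound 2 `COc1cc(Cl)cc(-c2nn(-c3cccc(NC(=O)c4ccc(Cl)c(Cl)c4)c3)cc2-c2ccncc2)c1` was tested in a functional assay on SF-268 cells (Homo sapiens) for inhibition, read by sulforhodamine B assay, with a stated time of 48 h, tested at 10 uM (a higher number here means a weaker effect of the compound at the concentration tested, a lower number a stronger effect), where compound 2 gives 82.4%. Among the three measured compounds it stands second highest: compound 3 `COc1cc(Cl)cc(-c2nn(-c3cccc(NC(=O)c4cccc(C(F)(F)F)c4)c3)cc2-c2ccncc2)c1` gives 77.3% and compound 1 `COc1cc(Cl)cc(-c2nn(-c3cccc(NC(=O)c4cc(C(F)(F)F)cc(C(F)(F)F)c4)c3)cc2-c2ccncc2)c1` gives 89.2%, both within the scatter of compound 2. Compound 4 `COc1cc(Cl)cc(-c2nn(-c3cccc(NC(=O)Nc4ccc(Cl)c(Cl)c4)c3)cc2-c2ccncc2)c1` differs from compound 2 at the carbonyl carbon: (3,4-dichlorophenyl)amino in place of 3,4-dichlorophenyl on a carbonyl carbon. The measured steps concern other parts of the molecule: a number 11.9 percentage points lower from compound 1 to compound 3 (beyond the scatter) and a number 5.1 percentage points lower from compound 2 to compound 3 (within the scatter). Among the measured compounds shown here, neither touches the carbonyl carbon, so no measured step bears directly on this change. Compound 4 is therefore expected to give 82%, between 66% and 98%, which means an expected step of a number 0.4 percentage points lower from compound 2 to compound 4 (within the scatter), not beyond the scatter.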

Compound 4, a percentage reported as activity, at one concentration (the size of the read-out at that concentration, not a potency): 25.3%
The estimate for compound 4 lay 56.7 percentage points above the measured number; measured number outside the range, below it.
By their numbers in this assay, from the lowest: compound 4; then compounds 3, 2 and 1 (each within the scatter of the next, the first and the last beyond it).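

In this assay, placing (3,4-dichlorophenyl)amino on the carbonyl carbon in place of 3,4-dichlorophenyl gives a number 57.1 percentage points lower from compound 2 to compound 4 (beyond the scatter) and turns this position from one of small differences into one of large effect. The same carbonyl-carbon position also gives a number 52 percentage points lower from compound 3 to compound 4 (beyond the scatter) when the group leaving is 3-(trifluoromethyl)phenyl. No available evidence accounts for this effect. As far as these compounds go, what remains open is whether a methylene or an oxygen linking the carbonyl carbon to the 3,4-dichlorophenyl ring would behave like the amino link. From the compounds shown here alone, it also remains open whether (3-(trifluoromethyl)phenyl)amino would give a similar number.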